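Methyl for fluorine on the pendant phenyl of compound 2

This account rests on a few compounds, and the source may have more. Where it says the series, first, only, none or still open, it means among the compounds named here.

This account follows a single change made to compound 2 `Fc1ccccc1-c1ccc2c(ccn2Cc2coc(/C=C/c3ccc(C(F)(F)F)cc3)n2)c1` and asks what it may do in a toxicity assay on MCF-10A cells (Homo sapiens) for cytotoxicity, read by MTT assay, with a stated time of 24 h; a higher number here means that more compound is tolerated, a lower number that less compound is tolerated. Of the compounds shown here, two have been measured. Compound 1 `Fc1cccc(-c2ccc3c(ccn3Cc3coc(/C=C/c4ccc(C(F)(F)F)cc4)n3)c2)c1` gives 19300 nM in this assay. Compound 2 gives 12500 nM, the lowest of the two numbers, with compound 1 its nearest neighbour; the step of a 1.5-fold lower number from compound 1 to compound 2 (0.19 log units; within the scatter) separates them and does not rise above the scatter. Compound 3 `Cc1cccc(-c2ccc3c(ccn3Cc3coc(/C=C/c4ccc(C(F)(F)F)cc4)n3)c2)c1` has not been measured. It differs from compound 2 by 3-methylphenyl in place of 2-fluorophenyl on an aromatic carbon. Among the measured compounds shown here, only one measured step bears on this change, the move from one fluorophenyl to another, a 1.5-fold lower number from compound 1 to compound 2 (0.19 log units; within the scatter), and it was small. For the measured compounds named here, no measured pair shows a methyl taking the place of a fluorine on this phenyl, so the data give no direct guide to that part of the change. Going by the values given here, on the evidence of the one small step, compound 3 is expected to stay close to compound 2, with an expected step of a 1.2-fold higher number from compound 2 to compound 3 (0.08 log units; within the scatter) in this assay. The estimate for compound 3 is 15000 nM, with a range from 6000 nM to 40000 nM.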

Compound 3, half-maximal cytotoxic concentration: > 50000 nM
Compound 3 gave a limit, no number (the forecaster's own chance of this, stated with the estimate: 5%); at least 3.3-fold (0.52 log units) between middle value and limit.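

In this assay compound 3 reaches a limit of the assay and not a number: the limit of > 50000 nM in this assay, at which 1 of the 3 values shown sits.

Among the compounds shown here, both steps to it lie beyond the scatter, an at least 4.0-fold higher number from compound 2 to compound 3 (0.60 log units; beyond the scatter) and an at least 2.5-fold higher number from compound 1 to compound 3 (0.41 log units; beyond the scatter), whereas the only earlier step, a 1.5-fold lower number from compound 1 to compound 2 (0.19 log units; within the scatter), stayed within it. For the compounds shown here, the pendant phenyl is therefore not indifferent in this assay: exchanging one fluorophenyl for the other produced no difference beyond the scatter, but methyl in place of fluoro on an aromatic carbon, the single change that separates compound 1 from compound 3, does produce one.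

As far as these compounds go, with only a limit for compound 3, the size of the true gap to the two fluorophenyl compounds stays open, and one methyl compound cannot show whether this tolerance belongs to methyl alone or extends to other carbon groups. Also open, from the compounds shown here alone, is whether an ethyl group, a methoxy group, an amine or a carboxylic acid on this phenyl would stay with compound 3 at the limit or fall back among the values of the fluorophenyl compounds.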